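Cytotoxicity notes on the thienyl pyridazinone sulfonamide series

A few compounds are considered here, and "the series" means these few. Any claim that something is new, unique, unknown or untested is made for them only; others in the source may bear on it.

Measured compounds:
- compound 1 `CCCS(=O)(=O)Nc1ccc2c(c1)S(=O)(=O)N=C(c1c(O)c(-c3cccs3)nn(CCC(C)C)c1=O)N2` — > 1000 nM
- compound 2 `CC(C)CCn1nc(-c2cccs2)c(O)c(C2=NS(=O)(=O)c3cc(S(=O)(=O)N(C)C)ccc3N2)c1=O` — "not determined" (no result reported)
- compound 3 `CCC(C)CCn1nc(-c2cccs2)c(O)c(C2=NS(=O)(=O)c3cc(NS(C)(=O)=O)ccc3N2)c1=O` — > 1000 nM

In an ADME assay on Huh-7 cells (Homo sapiens) for cytotoxicity, with a stated time of 72 h (on this read-out higher numbers stand for lower toxicity in this test and lower numbers for higher toxicity in this test), compound 1 gives > 1000 nM, which is a limit of the assay and not a number. For compound 2 this assay returns "not determined" (no result reported), so no value is available. Compound 3 gives > 1000 nM in this assay; this too is a limit and not a number, so compound 3 cannot be placed against compound 1 beyond the observation that both sit at the same limit, as noted in the limit of > 1000 nM in this assay, at which 2 of the 3 values shown sit. Going by the values given here, no step between measured compounds can be computed here, and no pattern is claimed from three entries of which one is missing.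

Compound 4 `CC(C)(C)Cn1nc(-c2cccs2)c(O)c(C2=NS(=O)(=O)c3cc(NS(C)(=O)=O)ccc3N2)c1=O` has not yet been tested in this assay. It differs from compound 3 by tert-butyl in place of 2-methylbutyl on a saturated chain carbon bound to an aromatic nitrogen. Both compounds share the remaining core with the thienyl and methanesulfonamide substituents unchanged. Given that compound 3 gives only a limit > 1000 nM in this assay, the step to compound 4 is expected to be none beyond the scatter, a step that the limit leaves unreadable from compound 3 to compound 4. Compound 4 is therefore expected at 2000 nM, within 800 nM to 6000 nM, most likely again reported only as a limit.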

Compound 4, half-maximal cytotoxic concentration: > 1000 nM
Compound 4: no number, only a limit (the forecaster's own chance of this, stated with the estimate: 80%); the middle value is on the limit's open side.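

In this assay compound 4 gives > 1000 nM, a limit and not a number. Going by these compounds alone, with compound 3 also at a limit, no step from compound 3 to compound 4 can be read: the limit of > 1000 nM in this assay, at which 3 of the 4 values shown sit. The compounds shown leave open whether tert-butyl in place of 2-methylbutyl changes the half-maximal cytotoxic concentration at all.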